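Replacing Dimethylamino with Benzylamino in a Cytotoxicity Series

The compounds below may be only part of what the source reports. "The series", "measured", "known", "first", "only" and "open" are said of these compounds alone.

In an ADME assay on A549 cells (Homo sapiens) for cytotoxicity, read by resazurin assay, with a stated time of 48 h (a lower number here means that less compound is tolerated, a higher number that more compound is tolerated), compound 1 (`CC(C)Nc1ccc(NC(=O)c2cc(Cl)ccc2O)c(Cl)c1`) gives 11000 nM. Compound 2 (`CN(C)c1ccc(NC(=O)c2cc(Cl)ccc2O)c(Cl)c1`) gives 85100 nM, the higher of the two numbers, so it is the better tolerated of this pair. Compound 3 (`O=C(Nc1ccc(NCc2ccccc2)cc1Cl)c1cc(Cl)ccc1O`) has not yet been measured. It carries benzylamino in place of dimethylamino on an aromatic carbon, meta to a chloro group and para to a large group (benzylamino in place of dimethylamino on an aromatic carbon).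

For the measured compounds named here, only one measured step bears on this change: a 7.7-fold higher number from compound 1 to compound 2 (0.89 log units; beyond the scatter), which brought dimethylamino in place of isopropylamino on an aromatic carbon. That step is modest but beyond the scatter. Compound 3 gives up the dimethylamino group, so a fall in this assay of similar size is expected rather than no change. Going by the values given here, the direction rests on this single step, and no measured compound carries benzylamino, so the size remains uncertain. The expected change is a 7.1-fold lower number from compound 2 to compound 3 (0.85 log units; beyond the scatter). For compound 3 the estimated value is 12000 nM, within an expected range of 3500 nM to 40000 nM.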

Compound 3, half-maximal cytotoxic concentration: 19700 nM
Compound 3: the middle estimate sits 1.6-fold (0.22 log units) below what was measured; the range from low to high includes it.
By their numbers in this assay, from the lowest: compounds 1 and 3 (each within the scatter of the next); then compound 2.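

At this position on the aromatic carbon, para to a large group, the step of a 4.3-fold lower number from compound 2 to compound 3 (0.64 log units; beyond the scatter) in this assay shows that the high number seen with dimethylamino does not carry over to benzylamino. The step of a 1.8-fold higher number from compound 1 to compound 3 (0.25 log units; within the scatter) puts benzylamino and isopropylamino together, so exchanging isopropyl for benzyl on this nitrogen, and with it bringing in a six-membered aromatic ring of carbon only, leaves no readable difference, and compound 2 alone stands apart from the other two. Compound 2 is also the only one of the three without a hydrogen on this nitrogen, but this is an observation across three structures, and no measurement at hand gives a reason for the gap.

As far as these compounds go, whether that nitrogen hydrogen goes with the lower numbers remains open, and methylamino, or a nitrogen carrying both a methyl and a benzyl group, would help to separate that reading from one based on the particular groups involved. From the compounds shown here alone, how a group with no nitrogen at this position, such as methoxy, would compare also remains open.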